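The source may report more compounds than this note shows. Statements on the series, on what has been measured and on what is new or still open speak of the compounds shown alone.

Measured in an ADME assay on HEK293 cells (Homo sapiens) for cytotoxicity, read by resazurin assay, with a stated time of 16 h; on this read-out lower numbers stand for an effect already at smaller amounts and higher numbers for an effect only at larger amounts of compound:
- compound 1 `COc1cc(/C=C/C(=O)CC(=O)/C=C/c2ccc(OCC=C(C)C)c(OC)c2)ccc1O`: > 500000 nM (a limit)
- compound 2 `COc1cc(/C=C/C(=O)CC(=O)/C=C/c2ccc(OCC=C(C)C)c(OC)c2)ccc1OCC=C(C)C`: > 1000000 nM (a limit)
- compound 3 `COc1cc(/C=C/C(=O)CC(=O)/C=C/c2ccc(OCCO)c(OC)c2)ccc1OCCO`: 20000 nM

As far as these compounds go, compound 1 gives only a limit, > 500000 nM, so its exact place on the scale is unknown. Compound 4 `COc1cc(/C=C/C(=O)CC(=O)/C=C/c2ccc(OC(=O)c3ccccc3)c(OC)c2)ccc1O` keeps the core of compound 1 but carries benzoyl in place of 3-methylbut-2-en-1-yl on an oxygen on an aromatic ring. Among the measured compounds shown here, the one measured step that bears on this, a step that the two limits leave unreadable from compound 1 to compound 2, also concerns a group on such an oxygen, but it joins two limits and gives no size. Compound 3 reads 20000 nM, which shows that a real number can be obtained with this core. A cautious move toward smaller amounts is therefore expected, with the estimated step being an at least 2.5-fold lower number from compound 1 to compound 4 (0.39 log units; beyond the scatter). For compound 4 the estimated value is 200000 nM, with an expected range of 30000 nM to 1000000 nM.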

Compound 4, half-maximal effective concentration: 94000 nM
Beside the measured number, compound 4's estimate is 2.1-fold (0.33 log units) above it; the range from low to high includes it.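

Among the compounds shown here, at this oxygen on an aromatic ring, the change from 3-methylbut-2-en-1-yl to benzoyl gives the first readable step in this assay (an at least 5.3-fold lower number from compound 1 to compound 4 (0.72 log units; beyond the scatter)). The group on this oxygen can therefore move the read-out beyond the usual scatter. That size is only a minimum, because compound 1 gives a limit and not a number: the limit of > 500000 nM in this assay, at which 1 of the 4 values shown sits.

Benzoyl brings both an aromatic ring and a carbonyl, and the compounds shown do not separate the two. Benzyl on the same oxygen, with the ring but no carbonyl, would separate them.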